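From 4-Acetylphenyl to 3-Methylphenyl on a Shared Core

The source may hold more compounds than are shown below. What is called first, only, known or untested is meant among the compounds shown, and "the series" means these compounds.

Within the data shown here, in a functional assay on ileum (Cavia porcellus) for antagonist activity (a lower number here means a stronger inhibitor, a higher number a weaker inhibitor), only two compounds have numbers so far. Compound 1 `CCCc1c(OCCCOc2ccccc2)ccc2c(O)c([N+](=O)[O-])c(=O)oc12` gives 540 nM, and compound 2 `CC(=O)c1ccc(OCCCOc2ccc3c(O)c([N+](=O)[O-])c(=O)oc3c2)cc1` gives 6100 nM. Compound 2 therefore holds the higher number of the pair, making it the weaker inhibitor by a gap beyond the usual scatter. Compound 3 `Cc1cccc(OCCCOc2ccc3c(O)c([N+](=O)[O-])c(=O)oc3c2)c1` changes one place in compound 2, with 3-methylphenyl in place of 4-acetylphenyl on an oxygen on a saturated carbon. Among the measured compounds shown here, no measured step covers this swap, and the two measured compounds differ in more than one place, so the guidance is thin. For the measured compounds named here, compound 1 at 540 nM shows only that much lower numbers occur in this small set. The estimated move is modest, a 2.2-fold lower number from compound 2 to compound 3 (0.34 log units; beyond the scatter), toward a lower number and close to the scatter. Compound 3 is estimated at 2800 nM, with an expected range from 800 nM to 9000 nM.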

Compound 3, half-maximal inhibitory concentration: 4400 nM
The estimate for compound 3 lay 1.6-fold (0.20 log units) below the measured number, and the stated range covers the measured number.
By their numbers in this assay, from the lowest: compound 1; then compounds 3 and 2 (each within the scatter of the next).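

The swap of 4-acetylphenyl for 3-methylphenyl gives a 1.4-fold lower number from compound 2 to compound 3 (0.14 log units; within the scatter) in this assay, so this pair cannot be told apart. Among these compounds, this offers the first direct reading at this place, on an oxygen on a saturated carbon: the 4-acetylphenyl group, with its hydrogen-bond acceptor and its double bond outside the ring, gives way to 3-methylphenyl, which has neither, with no change that this measurement can resolve. Nothing available explains why the two compounds read alike.

On these data alone, whether an amine or a carboxylic acid on this phenyl ring would move the number beyond the scatter remains open. Also open, as far as these compounds go, is which part of the swap matters, since the group and its numbered place on the ring change together here, and 4-methylphenyl would separate the two.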